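A few compounds are considered here, and "the series" means these few. Any claim that something is new, unique, unknown or untested is made for them only; others in the source may bear on it.

Among the measured compounds shown here, compound 3 `CC(Oc1ccc2c(=O)c(-c3ccc(O)cc3)coc2c1)C(=O)O` has the highest of the three numbers so far in an assay (Cricetulus griseus) for inhibition of aldehyde dehydrogenase, mitochondrial (Homo sapiens) (on this read-out higher numbers stand for weaker inhibition and lower numbers for stronger inhibition), with compound 3 giving 2500 nM. Compound 1 `CCCCCCOc1ccc2c(=O)c(-c3ccc(O)cc3)coc2c1` is closest, with compound 1 giving 1500 nM; compound 2 `CCOc1ccc2c(=O)c(-c3ccc(O)cc3)coc2c1` is furthest, with compound 2 giving 80 nM. The step of a 1.7-fold higher number from compound 1 to compound 3 (0.22 log units; within the scatter) is small, whereas a 31-fold higher number from compound 2 to compound 3 (1.49 log units; beyond the scatter) and a 19-fold lower number from compound 1 to compound 2 (1.27 log units; beyond the scatter) are large.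

Compound 4 `O=C(O)COc1ccc2c(=O)c(-c3ccc(O)cc3)coc2c1` is reached from compound 3 by the change hydrogen in place of methyl on a saturated chain carbon bound to a carbonyl carbon and an oxygen on an aromatic ring: the chain that ends in the carboxy group is shortened by one carbon, but the carboxy group itself stays. The step that bears most on this is a 31-fold higher number from compound 2 to compound 3 (1.49 log units; beyond the scatter), where the carboxy group entered and the number rose steeply. For the measured compounds named here, no measured step removes a methyl from the chain, so the effect of losing that one carbon is not directly known. Since the carboxy group remains in place, the expectation is that compound 4 stays close to compound 3, with the estimated step of no change at the digits printed from compound 3 to compound 4 (within the scatter) lying within the scatter. Compound 4 is therefore expected to give about 2500 nM in this assay, within a range from 1000 nM to 6000 nM.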

Compound 4, half-maximal inhibitory concentration: 1200 nM
The estimate for compound 4 lay 2.1-fold (0.32 log units) above the measured number; low and high end bracket the measured number.
By their numbers in this assay, from the lowest: compound 2; then compounds 4, 1 and 3 (each within the scatter of the next, the first and the last beyond it).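

In this assay, among the compounds shown here, the carbon that carries the carboxy group turns out to respond to a single methyl: taking that methyl away gives a 2.1-fold lower number from compound 3 to compound 4 (0.32 log units; beyond the scatter), a modest step that the earlier compounds could not show, since none of them isolated this one change. Keeping the carboxy group on the shorter carboxymethyl chain still leaves a large distance from the best number in the set, with a 15-fold higher number from compound 2 to compound 4 (1.18 log units; beyond the scatter), so a second compound now agrees with the earlier finding that a carboxy group on this chain goes with much weaker inhibition than the small chain of compound 2 does. Meanwhile, the comparison of carboxymethyl with hexyl gives a 1.3-fold lower number from compound 1 to compound 4 (0.10 log units; within the scatter), which means that two very different groups on this oxygen cannot be told apart in this assay, even though both sit far from compound 2.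

Going by these compounds, it remains open whether a propyl or butyl chain, or an amine or amide in place of the carboxy group, would keep the number near that of compound 2. No separate measurement offers an explanation for any of these steps.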